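Swapping Methyl for Methoxy on Compound 2

A few compounds are considered here, and "the series" means these few. Any claim that something is new, unique, unknown or untested is made for them only; others in the source may bear on it.

Compound 1 (`COc1ccc(OC)c(C(=O)/C=C/c2ccc(C)s2)c1`) gives (4500 nM)
Compound 2 (`COc1ccc(OC)c(C(=O)/C=C/c2ccc(OC(=O)/C=C/c3ccc(C)cc3)cc2)c1`) gives (29700 nM)

In a functional assay on A549 cells (Homo sapiens) for cytotoxicity, read by MTT assay (a lower number here means a stronger inhibitor, a higher number a weaker inhibitor), compound 2 has the higher of the two numbers, so it is the weaker inhibitor of the pair, and the gap to compound 1 lies beyond the scatter. Compound 3 (`COc1ccc(/C=C/C(=O)Oc2ccc(/C=C/C(=O)c3cc(OC)ccc3OC)cc2)cc1`) alters compound 2 in one place, with methoxy in place of methyl on an aromatic carbon, para to a large group (methoxy in place of methyl on an aromatic carbon). Going by the values given here, no measured pair shows this change, so the expectation is cautious. In this assay the expected step is a 1.2-fold lower number from compound 2 to compound 3 (0.07 log units; within the scatter) and so lies within the scatter. The estimate for compound 3 is 25000 nM (10000 nM to 60000 nM).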

Compound 3, half-maximal inhibitory concentration: 60400 nM
Compound 3: middle estimate off by 2.4-fold (0.38 log units), on the low side; the whole stated range lies below it.
By their numbers in this assay, from the lowest: compound 1; then compound 2; then compound 3.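

Going by these compounds alone, compound 3 gives the first direct reading of this change: in this assay, going from 4-methylphenyl to 4-methoxyphenyl gives a 2.0-fold higher number from compound 2 to compound 3 (0.31 log units; beyond the scatter). The swap therefore weakens the compound, and this place on the aromatic ring, para to a large group, responds to even a small change of group. Nothing measured here explains why the methoxy compound is weaker.

Going by these compounds, whether an amine, a fluorine atom or a longer chain such as ethoxy would strengthen or further weaken the compound at this place remains open. A single step also cannot show whether the same swap would act alike on another core, such as that of compound 1.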